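This account rests on a few compounds, and the source may have more. Where it says the series, first, only, none or still open, it means among the compounds named here.

Measured so far in an assay on cells for antagonist activity at transient receptor potential cation channel subfamily V member 1 (Homo sapiens), read by FLIPR and calcium flux, with a stated time of 6 min; a lower number here means a stronger inhibitor, a higher number a weaker inhibitor:

- compound 1 `CCCCN(C)c1cc(C(C)(C)C)ccc1CNC(=O)C(C)c1ccc(NS(C)(=O)=O)c(F)c1` gives 1 nM
- compound 2 `CC(C(=O)NCc1ccc(C(C)(C)C)cc1OCC(C)(C)C)c1ccc(NS(C)(=O)=O)c(F)c1` gives 3.8 nM
- compound 3 `CC(C)CCOc1cc(C(C)(C)C)ccc1CNC(=O)C(C)c1ccc(NS(C)(=O)=O)c(F)c1` gives 0.6 nM

Compound 3 carries the lowest of the three numbers, but the gap to compound 1, a 1.7-fold lower number from compound 1 to compound 3 (0.22 log units; within the scatter), lies within the scatter, so these two are not distinguished. The gap to compound 2 is clear: a 6.3-fold lower number from compound 2 to compound 3 (0.80 log units; beyond the scatter). From compound 1 to compound 2 the number goes a 3.8-fold higher number from compound 1 to compound 2 (0.58 log units; beyond the scatter).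

Compound 4 `CC(C(=O)NCc1ccc(C(C)(C)C)cc1OC1CCCC1)c1ccc(NS(C)(=O)=O)c(F)c1` keeps everything of compound 3 except the chain on the oxygen: cyclopentyl in place of isopentyl on an oxygen on an aromatic ring. Among the compounds with values here, no measured step swaps a chain for a ring of the same atom count, so the only guide is the pair of ethers, where a 6.3-fold lower number from compound 2 to compound 3 (0.80 log units; beyond the scatter) shows that the arrangement of the five carbons on the oxygen shifts the number beyond the scatter. Whether a five-membered ring behaves more like the neopentyl or the isopentyl arrangement is not settled by these data. Compound 4 is therefore expected to land between the two ethers in this assay, with the expected step being a 2.5-fold higher number from compound 3 to compound 4 (0.40 log units; beyond the scatter). The estimate for compound 4 is 1.5 nM, with a range of 0.5 nM to 4.5 nM.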

Compound 4, inhibition constant: 1.8 nM
Compound 4: middle estimate off by 1.2-fold (0.08 log units), on the low side, within the range that was stated.
By their numbers in this assay, from the lowest: compounds 3, 1 and 4 (each within the scatter of the next, the first and the last beyond it); then compound 2.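

In this assay, the ring at this position gives a number that differs from both open-chain ethers, although each group on the oxygen has five carbons and no hydrogen-bond donors or acceptors: cyclopentyl in place of isopentyl gives (a 3.0-fold higher number from compound 3 to compound 4 (0.48 log units; beyond the scatter)), and cyclopentyl in place of neopentyl gives (a 2.1-fold lower number from compound 2 to compound 4 (0.32 log units; beyond the scatter)), so carbon count alone does not set the number across compound 2, compound 3 and compound 4. Exchanging the butyl(methyl)amino group for cyclopentyloxy on the aromatic carbon gives (a 1.8-fold higher number from compound 1 to compound 4 (0.26 log units; within the scatter)), so compound 1 and compound 4 are not distinguished in this assay. Nothing available here accounts for the differences among these ethers.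

How the number responds to ring size on this oxygen remains open, since cyclobutyl and cyclohexyl ethers are not among the compounds shown, as does the effect of a straight pentyl chain in place of the branched chains. Also open, going by these compounds, is whether the same differences among the three ethers would hold if a trifluoromethyl group replaced the tert-butyl group on the core.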